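Methoxy Added to Compound 1: Tolerability Expected to Stay High

The source may report more compounds than this note shows. Statements on the series, on what has been measured and on what is new or still open speak of the compounds shown alone.

Measured compounds in an ADME assay on U2OS cells (Homo sapiens) for cytotoxicity, with a stated time of 96 h; a lower number here means that less compound is tolerated, a higher number that more compound is tolerated:
Compound 1 `CC1=C(C(=O)OCCc2ccccc2)C(c2ccncc2)C2=C(CC(c3ccccc3)CC2=O)N1`: > 200000 nM, a limit of the assay, not a number.
Compound 2 `CC(C)COc1ccc(CN(Cc2ccncc2)S(=O)(=O)c2ccc(F)c(F)c2)cc1`: 11500 nM.
Compound 3 `O=C(COc1ccc(-c2ccccc2)cc1)N1CCN(S(=O)(=O)c2ccc(F)cc2)CC1`: > 200000 nM, also a limit of the assay.

Compound 1 sits at the upper edge of what this assay can report. Its value is a limit, and it shares that limit with compound 3, so two of the three measured compounds show no toxicity up to the point where measurement stops; only compound 2 gives a real number. The piece follows a single change from compound 1 to compound 4 `COc1ccc(C2CC(=O)C3=C(C2)NC(C)=C(C(=O)OCCc2ccccc2)C3c2ccncc2)cc1`: methoxy in place of hydrogen on an aromatic carbon. Among the measured compounds shown here, no step between measured compounds is available to tell how much such a change can move the read-out in this assay.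

The step from compound 1 to compound 4 is expected to be none beyond the scatter, and the estimate a number no higher from compound 1 to compound 4 (the limit leaves the size open) reflects that, because compound 1 already stands at the limit of > 200000 nM in this assay, at which 2 of the 3 values shown sit, and a small addition of this kind gives no reason to expect a different outcome. Compound 4 is therefore expected to give about 200000 nM, within the range 60000 nM to 400000 nM, most likely again as a limit rather than a number.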

Compound 4, half-maximal cytotoxic concentration: 19300 nM
Compound 4: the middle estimate sits 10-fold (1.02 log units) above what was measured, outside the stated range (below it).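

In this assay, the change from phenyl to 4-methoxyphenyl, on a ring carbon para to a large group, gives an at least 10-fold lower number from compound 1 to compound 4 (1.01 log units; beyond the scatter), so less compound is tolerated after this one small addition. Among the compounds shown here, this shows that the place is not silent in this assay, something the earlier compounds could not show, since no pair among them differed in one place. Compound 4 also gives this core a real number, 19300 nM, against which later changes at the same place can be read. The full size of the step stays unknown because compound 1 carries only a limit: the limit of > 200000 nM in this assay, at which 2 of the 4 values shown sit.

The compounds shown leave open whether methoxy itself matters or whether other groups at this place, such as a hydroxyl, a fluorine, an amine or a longer ether chain like ethoxy, would lower the number just as far. They also leave open whether the same addition would have a similar effect on a different core, and a single step cannot say why the number falls.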